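This account rests on a few compounds, and the source may have more. Where it says the series, first, only, none or still open, it means among the compounds named here.

Compound 3 `COc1cc(O)c2c(=O)n(-c3ccccc3)ccc2c1` carries a hydroxy group on the shared core and an unsubstituted phenyl on the ring nitrogen, yet in a functional assay on A-431 cells (Homo sapiens) for antiproliferative activity, read by MTT assay, with a stated time of 72 h (a higher number here means a weaker inhibitor, a lower number a stronger inhibitor), compound 3 shows "not determined" (no result reported), so its standing there cannot be placed on any number. Its neighbours give some orientation. Compound 1 `COc1cc(OC)c2c(=O)n(-c3cccc(C(=O)N4CCCCC4)c3)ccc2c1`, the dimethoxy analogue bearing the same amide as the target, shows 15300 nM in this assay. Compound 2 `C#Cc1cccc(-n2ccc3cc(OC)cc(O)c3c2=O)c1`, which keeps the hydroxy group and carries an ethynyl substituent instead, shows 4440 nM in this assay. Compound 4 `COc1cc(O)c2c(=O)n(-c3cccc(C(=O)N4CCCCC4)c3)ccc2c1` arises from compound 3 by (piperidin-1-yl)carbonyl in place of hydrogen on an aromatic carbon. Among the compounds with values here, with no step measured for this change, only a modest shift is anticipated. Compound 4 is expected to give about 8000 nM in this assay, within 2000 nM to 30000 nM.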

Compound 4, half-maximal inhibitory concentration: 2250 nM
Compound 4: middle estimate off by 3.6-fold (0.55 log units), on the high side; the measured number falls inside the stated range.
By their numbers in this assay, from the lowest: compounds 4 and 2 (each within the scatter of the next); then compound 1.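

Swapping ethynyl for (piperidin-1-yl)carbonyl on the aromatic carbon gives a 2.0-fold lower number from compound 2 to compound 4 (0.30 log units; within the scatter) in this assay, so these two groups are not told apart here. With that amide held fixed, hydrogen in place of methyl on an oxygen on an aromatic ring gives a 6.8-fold lower number from compound 1 to compound 4 (0.83 log units; beyond the scatter) and is the only step shown that lies beyond the scatter. No supporting data are available to explain either step.

Without a value for compound 3, the effect of adding the amide to its unsubstituted phenyl cannot be read. As far as these compounds go, it also remains open how a carboxylic acid or an amine at this position would compare.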